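The source may hold more compounds than are shown below. What is called first, only, known or untested is meant among the compounds shown, and "the series" means these compounds.

Of the compounds shown here, three built on related cores have been tested in a functional assay on WM 266-4 cells (Homo sapiens) for antiproliferative activity, read by MTT assay, with a stated time of 24 h; a lower number here means a stronger inhibitor of growth, a higher number a weaker inhibitor of growth. Compound 1 `COc1ccc(C2=NN(C(=O)c3cncc(Br)c3)C(c3ccc(OCc4ccccc4)cc3)C2)cc1` gives 6240 nM. Compound 2 `COc1ccc(C2=NN(C(=O)c3ccc(Cl)nc3)C(c3ccc(OCc4ccccc4)cc3)C2)cc1` differs from compound 1 in one place only, (6-chloropyridin-3-yl in place of 5-bromopyridin-3-yl on a carbonyl carbon). In this assay compound 2 gives 10600 nM. The size of that step is a 1.7-fold higher number from compound 1 to compound 2 (0.23 log units; within the scatter). Compound 3 `O=C(c1cncc(Br)c1)N1N=C(c2ccc(Cl)cc2)CC1c1ccc(Cl)cc1` sits on a second core; the difference between the core of compound 3 and the core of compound 1 is not broken down here. In this assay, among the compounds with values here, compound 3 gives 6090 nM, a number that lies close to the one for compound 1.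

Compound 4 `O=C(c1ccc(Cl)nc1)N1N=C(c2ccc(Cl)cc2)CC1c1ccc(Cl)cc1` has not yet been measured. It stands to compound 3 exactly as compound 2 stands to compound 1: the change is 6-chloropyridin-3-yl in place of 5-bromopyridin-3-yl on a carbonyl carbon, and the place of the change is described in the same words for both pairs, a carbonyl carbon whose other neighbour is an amide-type nitrogen in a ring. It is therefore the same change, carried onto the second core.

Within the data shown here, the only guide to what compound 4 will do is the single measured example of this change together with the starting point, compound 3, which gives 6090 nM. The earlier step was a 1.7-fold higher number from compound 1 to compound 2 (0.23 log units; within the scatter). On that footing the expected step is a 1.4-fold higher number from compound 3 to compound 4 (0.14 log units; within the scatter). For compound 4 the estimate in this assay is 8500 nM, with a likely range from 4000 nM to 18000 nM.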

Compound 4, concentration for 50% growth inhibition: 9890 nM
Compound 4: middle estimate off by 1.2-fold (0.07 log units), on the low side; the measured number falls inside the stated range.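

In this assay, putting 6-chloropyridin-3-yl in place of 5-bromopyridin-3-yl on the carbonyl carbon of the second core gives a 1.6-fold higher number from compound 3 to compound 4 (0.21 log units; within the scatter). Set beside the earlier example on the first core, the same change comes out at much the same size on both cores, which is what would be expected if the size of this step did not depend on the core: the same change on two cores in this assay, a 1.7-fold higher number (0.23 log units; within the scatter) from compound 1 to compound 2 and a 1.6-fold higher number (0.21 log units; within the scatter) from compound 3 to compound 4, 1.0-fold (0.02 log units) apart, within the scatter of two such steps. This agreement does not show that the change truly alters growth inhibition, as each step on its own lies within the scatter, and two cores say nothing firm about how the change would behave on a third.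

All four compounds carry either 5-bromopyridin-3-yl or 6-chloropyridin-3-yl on the carbonyl carbon, and the halogen and its numbered position differ together in this change, so the compounds shown cannot separate the two; 5-chloropyridin-3-yl or 6-bromopyridin-3-yl would be needed for that. Going by these compounds, it also remains open whether a clearer step would appear with a quite different group in this place, such as an amine, a carboxylic acid or a longer chain.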